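Aryl swaps on a shared core and HeLa cytotoxicity

The source may report more compounds than this note shows. Statements on the series, on what has been measured and on what is new or still open speak of the compounds shown alone.

Compound 1 `COc1nc(C(C)(C)C)ccc1[C@@H](c1ccccc1)[C@@](O)(CCN(C)C)c1cccc2ccccc12`: > 64 ug/mL
Compound 2 `COc1nc(-c2ccc(Br)cc2)ccc1[C@@H](c1ccccc1)[C@@](O)(CCN(C)C)c1cccc2ccccc12`: > 64 ug/mL
Compound 3 `COc1nc(-c2ccsc2)ccc1[C@@H](c1ccccc1)[C@@](O)(CCN(C)C)c1cccc2ccccc12`: > 64 ug/mL

Three compounds share a core and differ only in one group on an aromatic carbon. In a toxicity assay on HeLa cells (Homo sapiens) for cytotoxicity (on this read-out higher numbers stand for lower toxicity in this test and lower numbers for higher toxicity in this test), compound 1 gives > 64 ug/mL, which is a limit of the assay rather than a number. Compound 2 gives > 64 ug/mL in this assay, again a limit. Compound 3 stands at > 64 ug/mL in this assay, also a limit. The step that the two limits leave unreadable from compound 1 to compound 2 cannot be sized. Neither can a step that the two limits leave unreadable from compound 1 to compound 3 or a step that the two limits leave unreadable from compound 2 to compound 3. Within the data shown here, what the measured set does show is the limit of > 64 ug/mL in this assay, at which 3 of the 3 values shown sit, so no compound so far has reached a readable toxicity.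

Compound 4 `COc1ccc(-c2ccc([C@@H](c3ccccc3)[C@@](O)(CCN(C)C)c3cccc4ccccc34)c(OC)n2)cc1` is not yet measured. It differs from compound 3 in this way: 4-methoxyphenyl in place of thiophen-3-yl on an aromatic carbon. Among the measured compounds shown here, the only comparable changes, from a tert-butyl to a 4-bromophenyl or a thiophen-3-yl, and between those two aryl groups, all left the read-out at the limit, and the change to 4-methoxyphenyl is of the same kind. Compound 4 is therefore expected to give 90 ug/mL in this assay, with a range from 40 ug/mL to 250 ug/mL. The expected step that the limit leaves unreadable from compound 3 to compound 4 is none beyond the scatter, and most likely the assay will again report only a limit for compound 4.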

Compound 4, half-maximal cytotoxic concentration: > 64 ug/mL
Compound 4: only a limit was reported; the forecaster's own chance of this, stated with the estimate: 80%; the middle value does not contradict the limit.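

In this assay compound 4 gives > 64 ug/mL, which is a limit of the assay rather than a number. No step to compound 4 from compound 1, compound 2 or compound 3 can be read, and the whole set now stands at one limit: the limit of > 64 ug/mL in this assay, at which 4 of the 4 values shown sit.

The compounds shown leave open how far these four differ in toxicity, and whether any group at this place gives a readable value.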